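Trimming a Propyl to Ethyl on a Triazine Herbicide

The compounds below may be only part of what the source reports. "The series", "measured", "known", "first", "only" and "open" are said of these compounds alone.

The compounds share one core bearing a chlorine, a phenylethylamino group and a variable amino substituent. Compound 1 `CCNc1nc(Cl)nc(N[C@H](C)c2ccccc2)n1` carries an ethylamino group, while compound 2 `CCCN(CC)c1nc(Cl)nc(N[C@@H](C)c2ccccc2)n1` carries an ethyl(propyl)amino group and the opposite configuration at the phenylethyl carbon. In an ADME assay on the whole organism for inhibition, with Echinochloa crus-galli var. formosensis as the target, with a stated time of 4 days (a lower number here means a stronger inhibitor, a higher number a weaker inhibitor), compound 1 gives 2690 nM and compound 2 gives 282 nM. Of the two numbers, compound 2 shows the lower one, and the gap to compound 1 lies beyond the usual scatter, so compound 2 is the stronger inhibitor of the pair.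

Compound 3 `CCN(CC)c1nc(Cl)nc(N[C@@H](C)c2ccccc2)n1` is the diethylamino analogue and remains to be measured in this assay. Its difference from compound 2 is hydrogen in place of methyl on a saturated chain carbon, two bonds along the chain from a nitrogen on an aromatic ring. Within the data shown here, no step between two measured compounds of this kind exists, so the effect of this change is not anchored by any measured pair. Given that compound 2 gives 282 nM, the expected step from compound 2 to compound 3 is a 1.5-fold higher number from compound 2 to compound 3 (0.17 log units; within the scatter), a small loss that may fall within the scatter. Compound 3 is accordingly expected to give about 420 nM, with a range from 150 nM to 1200 nM.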

Compound 3, half-maximal inhibitory concentration: 257 nM
The estimate for compound 3 lay 1.6-fold (0.21 log units) above the measured number; measured number inside the range.
By their numbers in this assay, from the lowest: compounds 3 and 2 (each within the scatter of the next); then compound 1.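

In this assay, among these compounds, cutting the ethyl(propyl)amino group back to diethylamino gives a 1.1-fold lower number from compound 2 to compound 3 (0.04 log units; within the scatter), which is the first measured step at this position. It shows that, for this pair, with the configuration at the phenylethyl carbon the same in both compounds, hydrogen in place of methyl on a saturated chain carbon, two bonds along the chain from a nitrogen on an aromatic ring, leaves no change that can be told from the scatter. This single step shows what the propyl to ethyl change does on this background only, and nothing at hand accounts for its small size.

From the compounds shown here alone, it remains open whether the same tolerance extends to a longer chain such as butyl, to a branched chain such as isopropyl, or to a chain ending in a hydroxyl group or an amine. Compound 1 differs from compound 2 and compound 3 both in its amino substituent and in its configuration, so the separate contributions of the second alkyl group on the nitrogen and of the configuration at the phenylethyl carbon also stay unresolved.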